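This account rests on a few compounds, and the source may have more. Where it says the series, first, only, none or still open, it means among the compounds named here.

Two compounds share one core and differ only in the aryl group on one side. Compound 1 `COc1cc(/C=C2\CCC/C(=C\c3ccccc3[N+](=O)[O-])C2=O)cc(OC)c1OC` carries a trimethoxyphenyl group, and in a functional assay on MOLT-4 cells (Homo sapiens) for cytotoxicity, with a stated time of 72 h (a lower number here means a stronger inhibitor, a higher number a weaker inhibitor), compound 1 gives 702 nM. Compound 2 `CN(C)c1ccc(/C=C2\CCC/C(=C\c3ccccc3[N+](=O)[O-])C2=O)cc1` carries a dimethylaminophenyl group instead, and in this assay compound 2 gives 122000 nM, the higher of the two numbers by a wide margin, so compound 2 is the weaker of the pair.

Compound 3 `Cc1ccc(/C=C2\CCC/C(=C\c3ccccc3[N+](=O)[O-])C2=O)cc1` takes the structure of compound 2 one step further: methyl in place of dimethylamino on an aromatic carbon. Among the compounds with values here, no measured pair shows the effect of this exact change, so its size cannot be read from the data. Because compound 2 sits at 122000 nM while compound 1 sits at 702 nM, a move back toward a lower number seems more likely than a further rise, but with little confidence. Compound 3 is therefore expected to give about 12000 nM, somewhere from 2000 nM to 70000 nM. That expectation corresponds to a step of a 10-fold lower number from compound 2 to compound 3 (1.01 log units; beyond the scatter).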

Compound 3, half-maximal inhibitory concentration: 7520 nM
For compound 3 the middle estimate is 1.6-fold (0.20 log units) above the measured one; the measured number falls inside the stated range.
By their numbers in this assay, from the lowest: compound 1; then compound 3; then compound 2.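

In this assay, replacing dimethylamino with methyl on this aromatic carbon gives a 16-fold lower number from compound 2 to compound 3 (1.21 log units; beyond the scatter), a large step. The earlier pair changed the whole substitution of this aryl ring, whereas this pair changes a single group and leaves everything else in place, showing that this one position alone can shift the number substantially. Nothing measured here explains why the step is this large.

The compounds shown leave open how other groups at this position would compare, such as a primary amine, a methoxy group, a chlorine atom or a longer chain like ethyl. They also leave open whether swapping dimethylamino for methyl would have a similar effect if the nitrophenyl group on the other side of the shared core were replaced.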